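Oxindole series: chloro for phenoxy on the aryl ring

This account rests on a few compounds, and the source may have more. Where it says the series, first, only, none or still open, it means among the compounds named here.

Compound 1 `Cc1ccc2nc(Cl)c(/C=C3\C(=O)N(c4c(Cl)cccc4Cl)c4ccccc43)cc2c1` has no result in a functional assay on B16-F10 cells (Homo sapiens) for cytotoxicity against B16-F10 (Mus musculus), read by MTT assay, with a stated time of 72 h (on this read-out lower numbers stand for an effect already at smaller amounts and higher numbers for an effect only at larger amounts of compound), "not determined" (no result reported). Compound 2 `O=C1/C(=C\c2cccc(Oc3ccccc3)c2)c2ccccc2N1c1c(Cl)cccc1Cl` is reported there only as a limit, > 100 ug/mL, the only entry of this kind (the limit of > 100 ug/mL in this assay, at which 1 of the 2 values shown sits). Compound 3 `O=C1/C(=C\c2cccc(Cl)c2)c2ccccc2N1c1c(Cl)cccc1Cl` carries the change (chloro in place of phenoxy on an aromatic carbon), chloro in place of phenoxy on an aromatic carbon. Going by the values given here, no step between measured compounds exists for guidance, so no shift beyond the scatter is expected in this assay. Compound 3 is estimated at 150 ug/mL, with a range of 40 ug/mL to 500 ug/mL, the expected step being a step that the limit leaves unreadable from compound 2 to compound 3.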

Compound 3, concentration for half-maximal effect: 8 ug/mL
Beside the measured number, compound 3's estimate is 19-fold (1.27 log units) above it, outside the stated range (below it).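

In this assay, this position, meta to a large group, responds strongly to the change: chloro in place of phenoxy gives an at least 12-fold lower number from compound 2 to compound 3 (1.09 log units; beyond the scatter). Compound 3 is the first compound shown with a single number rather than a limit. Compound 2 is held at a limit, so the step gives only a minimum size: the limit of > 100 ug/mL in this assay, at which 1 of the 3 values shown sits.

As far as these compounds go, whether the drop depends on chloro itself or on the departure of phenoxy stays open; methoxy, an amine or a carboxylic acid at this position would help separate the two. From the compounds shown here alone, whether the step carries over to other aryl groups also remains open.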